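The source may hold more compounds than are shown below. What is called first, only, known or untested is meant among the compounds shown, and "the series" means these compounds.

Compound 1, `C/C(=C\CC/C(C)=C/CC[C@@H]1[C@@]2(C)CCC(=O)C(C)(C)[C@H]2CC[C@@]1(C)O)CC/C=C(\C)C(=O)OCc1cn(-c2cccc(Cl)c2)nn1`: 91800 nM in a functional assay on U-87MG ATCC cells for antiproliferative activity against U-87 MG (Homo sapiens), read by MTT assay, with a stated time of 48 h; a lower number here means a stronger inhibitor, a higher number a weaker inhibitor.
Compound 2, `C/C(=C\CC/C(C)=C/CC[C@@H]1[C@@]2(C)CCC(=O)C(C)(C)[C@H]2CC[C@@]1(C)O)CC/C=C(\C)C(=O)OCc1cn(-c2ccc(Br)cc2)nn1`: > 150000 nM, a limit of this assay.
Compound 3, `C/C(=C\CC/C(C)=C/CC[C@@H]1[C@@]2(C)CCC(=O)C(C)(C)[C@H]2CC[C@@]1(C)O)CC/C=C(\C)C(=O)OCc1cn(-c2cccc(F)c2)nn1`: > 150000 nM, a limit of this assay.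

Compound 3 stands at the upper edge of what this assay reports. Its value is a limit, not a number, and it shares that position with one other compound, as the limit of > 150000 nM in this assay, at which 2 of the 3 values shown sit, records. Going by the values given here, compound 1 is the only compound with a measured number. The step of an at least 1.6-fold higher number from compound 1 to compound 3 (0.21 log units; that floor lies within the scatter) therefore has a floor only, and the step that the two limits leave unreadable from compound 2 to compound 3 cannot be read at all, since both of its ends are limits.

Compound 4, `C/C(=C\CC/C(C)=C/CC[C@@H]1[C@@]2(C)CCC(=O)C(C)(C)[C@H]2CC[C@@]1(C)O)CC/C=C(\C)C(=O)OCc1cn(-c2cccc([N+](=O)[O-])c2)nn1`, has not been measured. It differs from compound 3 by nitro in place of fluoro on an aromatic carbon. Among the compounds with values here, no measured step involves a nitro group, so nothing among the three compounds speaks directly to this change. What the three compounds do show is that every variation of the halogen on the phenyl ring has left the compounds weak, with two of the three at the limit. Compound 4 is therefore expected to remain weak, with a step of a number no higher from compound 3 to compound 4 (the limit leaves the size open) that is not expected to rise above the scatter. For compound 4 the estimate in this assay is 150000 nM, spanning 60000 nM to 300000 nM, and it is quite possible that only a limit will be reported.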

Compound 4, half-maximal inhibitory concentration: 134000 nM
Compound 4: middle estimate off by 1.1-fold (0.05 log units), on the high side; the range from low to high includes it.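

In this assay compound 4 gives a measured number, 134000 nM, so the nitro group at this place, meta to a large group, yields a readable value. The fluoro of compound 3 gives only a limit. Against the two limits only floors can be read, an at least 1.1-fold lower number from compound 3 to compound 4 (0.04 log units; that floor lies within the scatter) and an at least 1.1-fold lower number from compound 2 to compound 4 (0.04 log units; that floor lies within the scatter), so neither comparison shows a real difference. Going by these compounds alone, the one step between two measured numbers, a 1.5-fold higher number from compound 1 to compound 4 (0.16 log units; within the scatter), does not separate nitro from chloro, which means that the first group at this place that is not a halogen leaves the value in the same high range as the chloro of compound 1.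

How far the two limit compounds actually lie from compound 4 stays unknown: the limit of > 150000 nM in this assay, at which 2 of the 4 values shown sit. The compounds shown also leave open whether a quite different group on the phenyl ring, such as an amine or a carboxylic acid, would move the value beyond the scatter, and whether any change to this ring can do so at all.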